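Bromo in Place of Chloro: Expecting No Real Step

A few compounds are considered here, and "the series" means these few. Any claim that something is new, unique, unknown or untested is made for them only; others in the source may bear on it.

Measured in an assay on 1321N1 cells for antagonist activity at P2Y purinoceptor 6 (Mus musculus), read by FLIPR and calcium flux; on this read-out lower numbers stand for stronger inhibition and higher numbers for weaker inhibition:
Compound 1 `O=[N+]([O-])C1=Cc2cc(C#Cc3ccc(CO)cc3)ccc2OC1C(F)(F)F` gives 31600 nM
Compound 2 `O=[N+]([O-])C1=Cc2cc(Cl)ccc2OC1C(F)(F)F` gives 30800 nM

Compound 2 has the lower of the two numbers, yet compound 1 sits so close that the two cannot be told apart. Compound 3 `O=[N+]([O-])C1=Cc2cc(Br)ccc2OC1C(F)(F)F` is unmeasured; it differs from compound 2 only by bromo in place of chloro on an aromatic carbon. Within the data shown here, no pair of measured compounds differing in one place exists here, so nothing measured speaks to this swap. The expected step is a 1.0-fold lower number from compound 2 to compound 3 (0.01 log units; within the scatter), none beyond the scatter. Compound 3 is therefore estimated at 30000 nM, between 12000 nM and 80000 nM in this assay.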

Compound 3, half-maximal inhibitory concentration: 20200 nM
Compound 3: middle estimate off by 1.5-fold (0.17 log units), on the high side, within the range that was stated.
By their numbers in this assay, from the lowest: compounds 3, 2 and 1 (each within the scatter of the next).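

In this assay, bromo in place of chloro on this aromatic carbon gives a 1.5-fold lower number from compound 2 to compound 3 (0.18 log units; within the scatter), the first one-place comparison available here. At this position, the two halogens cannot be told apart on the shared core. No measured property of either group is available to account for this.

On these data alone, whether an amine, a carboxylic acid or a methoxy group at the same carbon would give a number beyond the scatter remains open. Also open, as far as these compounds go, is whether bromo in place of chloro would give a similarly small step elsewhere on the core.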